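Aryl ether variation on a thromboxane synthase inhibitor core

The source may report more compounds than this note shows. Statements on the series, on what has been measured and on what is new or still open speak of the compounds shown alone.

Compound 1 `O=C(O)CC/C=C\CC1COC(c2ccc(Cl)cc2Cl)OC1c1cccnc1`: 42 nM
Compound 2 `O=C(O)CC/C=C\CC1COC(c2ccsc2)OC1c1cccnc1`: 500 nM
Compound 3 `CSc1ccc(OC(C)(C)C2OCC(C/C=C\CCC(=O)O)C(c3cccnc3)O2)c([N+](=O)[O-])c1`: 22 nM

Of the compounds shown here, three have been measured in an assay for inhibition of Thromboxane-A synthase (Homo sapiens), using microsomes; on this read-out higher numbers stand for weaker inhibition and lower numbers for stronger inhibition. Compound 3 has the lowest of the three numbers; compound 1 sits within the scatter of it, while compound 2 lies well beyond. Within the data shown here, the one step measured between neighbours differing in a single place, a 12-fold higher number from compound 1 to compound 2 (1.08 log units; beyond the scatter), concerns the aryl group on the saturated ring carbon of the shared core and is large.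

Compound 4 `CC(C)(C)c1ccc(OC(C)(C)C2OCC(C/C=C\CCC(=O)O)C(c3cccnc3)O2)cc1` differs from compound 3 elsewhere: a group of 10 heavy atoms (10 carbon; one six-membered aromatic ring of carbon only) in place of a group of 11 heavy atoms (7 carbon, 1 nitrogen, 2 oxygen, 1 sulfur; one six-membered aromatic ring of carbon only), on an oxygen on a saturated carbon. Among the measured compounds shown here, no measured pair probes this ether-bound aryl group, so the step from compound 1 to compound 2 bears on it only as a reminder that aryl exchanges on this core can move the number by a large amount. For the measured compounds named here, with no direct precedent, a modest shift is the most that can be expected from the data for compound 4, with a wide range to allow for a change of either direction; the expected step is a 1.8-fold higher number from compound 3 to compound 4 (0.26 log units; within the scatter). In this assay compound 4 is therefore estimated at 40 nM, within a range from 10 nM to 160 nM.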

Compound 4, half-maximal inhibitory concentration: 280 nM
The estimate for compound 4 lay 7.0-fold (0.85 log units) below the measured number; measured number outside the range, above it.
By their numbers in this assay, from the lowest: compounds 3 and 1 (each within the scatter of the next); then compounds 4 and 2 (each within the scatter of the next).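

In this assay, the aryl group on the oxygen on a saturated carbon proves to be no passive part of the molecule: replacing the group of compound 3 with 4-(tert-butyl)phenyl gives a 13-fold higher number from compound 3 to compound 4 (1.10 log units; beyond the scatter). The earlier compounds shown here showed a large step only for the aryl group on the saturated ring carbon, whereas this pair shows that a large step also occurs at this second site, even though both groups hold one six-membered aromatic ring of carbon only and differ little in heavy-atom count. What the exchange does change is the composition, with the nitrogen, the sulfur and the two oxygens of the departing group, and its 3 hydrogen-bond acceptors, all gone in the entering group, but no available evidence explains the step.

Among these compounds, the single pair changes the nitro group, the methylthio group and the tert-butyl group together, so it leaves open which of them carries the step. Going by these compounds, how a plain phenyl, or a phenyl bearing only a nitro group, would read on this oxygen also remains open.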